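A few compounds are considered here, and "the series" means these few. Any claim that something is new, unique, unknown or untested is made for them only; others in the source may bear on it.

Going by the values given here, compound 2 `CN(C(=O)c1ccccc1)c1ccc2[nH]c(-c3n[nH]c4ccccc34)cc2n1` gives 10600 nM in a functional assay on HCT-116 cells (Homo sapiens) for antiproliferative activity, read by MTT assay, with a stated time of 72 h; on this read-out higher numbers stand for weaker inhibition and lower numbers for stronger inhibition; compound 1 `CCC(=O)N(C)c1ccc2[nH]c(-c3n[nH]c4ccccc34)cc2n1` gives 10800 nM, and the two numbers sit within the scatter of each other, the only step so far being a 1.0-fold lower number from compound 1 to compound 2 (0.01 log units; within the scatter). Compound 3 `CN(C(=O)c1ccc(Cl)cc1)c1ccc2[nH]c(-c3n[nH]c4ccccc34)cc2n1` carries chloro in place of hydrogen on an aromatic carbon. Among the compounds with values here, no measured step touches a substituent on the benzoyl ring, and the one known step, phenyl in place of ethyl on a carbonyl carbon, moved nothing beyond the scatter, so no step beyond the scatter is expected here either. Compound 3 is estimated at 10000 nM, within 4000 nM to 25000 nM, an expected step of a 1.1-fold lower number from compound 2 to compound 3 (0.03 log units; within the scatter).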

Compound 3, half-maximal inhibitory concentration: 3000 nM
Compound 3: the middle estimate sits 3.3-fold (0.52 log units) above what was measured; the whole stated range lies above it.
By their numbers in this assay, from the lowest: compound 3; then compounds 2 and 1 (each within the scatter of the next).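

In this assay, going by these compounds alone, the aromatic carbon para to a large group is the first place where a change moves the number beyond the scatter: chloro in place of hydrogen gives a 3.5-fold lower number from compound 2 to compound 3 (0.55 log units; beyond the scatter), whereas phenyl in place of ethyl did not. Replacing ethyl with 4-chlorophenyl gives a 3.6-fold lower number from compound 1 to compound 3 (0.56 log units; beyond the scatter), so this larger change also moves the number beyond the scatter. No measured evidence explains the step.

As far as these compounds go, it remains open whether fluoro, methoxy or an amine at this carbon would give a similar step. From the compounds shown here alone, it also remains open whether chloro elsewhere on the ring would do so.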